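The compounds below may be only part of what the source reports. "The series", "measured", "known", "first", "only" and "open" are said of these compounds alone.

Working notes on the series. The three measured compounds in an ADME assay on HOS cells (Homo sapiens) for cytotoxicity (on this read-out lower numbers stand for higher toxicity in this test and higher numbers for lower toxicity in this test), are compound 1 `CN(C)C1CCN(c2cccc3nc(CN(C)[C@H]4CCCc5cccnc54)cn23)CC1`, compound 3 `CN(Cc1cn2c(N3CCN4CCCC4C3)cccc2n1)[C@H]1CCCc2cccnc21` and compound 2 `CCCN(Cc1cn2c(N3CCN(C)CC3)cccc2n1)[C@H]1CCCc2cccnc21`. Compound 1 gives 3400 nM. Within the data shown here, compound 3 gives 3900 nM; the only single-point step measured so far, a 1.1-fold higher number from compound 1 to compound 3 (0.06 log units; within the scatter), exchanges a group of 9 heavy atoms on an aromatic carbon and lies within the scatter. Compound 2 gives 6700 nM; its gaps to compound 3 and to compound 1 are both within the usual scatter, so no order among the three can be read from these numbers.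

Compound 4 `CCCCN(Cc1cn2c(N3CCN(C)CC3)cccc2n1)[C@H]1CCCc2cccnc21` is not yet measured. It differs from compound 2 by methyl in place of hydrogen on a saturated chain carbon, three bonds along the chain from an amine nitrogen. Among the measured compounds shown here, no measured step bears on this chain: compound 1 and compound 2 differ in two places at once and give no single step, and the one single step known, a 1.1-fold higher number from compound 1 to compound 3 (0.06 log units; within the scatter), changes a different place and is itself within the scatter. Nothing here points to a shift beyond the scatter, so the expected step of no change at the digits printed from compound 2 to compound 4 (within the scatter) is set at none. Compound 4 is therefore estimated at 6700 nM, with an expected range from 2800 nM to 16000 nM.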

Compound 4, half-maximal cytotoxic concentration: 5300 nM
Compound 4: middle estimate off by 1.3-fold (0.10 log units), on the high side; the measured number falls inside the stated range.
By their numbers in this assay, from the lowest: compounds 1, 3, 4 and 2 (each within the scatter of the next).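

The chain on the amine nitrogen now has its first single-place reading in this assay: propyl to butyl gives a 1.3-fold lower number from compound 2 to compound 4 (0.10 log units; within the scatter). Among these compounds, at this place, then, methyl in place of hydrogen on a saturated chain carbon, three bonds along the chain from an amine nitrogen, does not separate the two compounds in this read-out, whereas the only earlier single-place step concerned a different part of the structure. No measurement at hand accounts for this reading.

One pair cannot show whether a longer chain such as hexyl would also stay within the scatter. It also leaves open how a carboxylic acid or a terminal amine at the end of this chain would read, and whether the same step would read alike with the other groups on the core.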